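From Methoxy to Bromo: Expected Cytotoxicity of Compound 4

This account rests on a few compounds, and the source may have more. Where it says the series, first, only, none or still open, it means among the compounds named here.

Compound 1 `COc1cccc(-c2csc(NC(=O)c3ccc([N+](=O)[O-])o3)n2)c1` was tested in an ADME assay on Vero cells (Chlorocebus sabaeus) for cytotoxicity, read by MTT assay, with a stated time of 72 h (on this read-out lower numbers stand for stronger inhibition and higher numbers for weaker inhibition), where it gives 58700 nM. Among the three measured compounds its number is the second highest, with compound 2 `COc1ccc(-c2csc(NC(=O)c3ccc([N+](=O)[O-])o3)n2)cc1` nearest at 63000 nM and compound 3 `O=C(Nc1nc(-c2cccc(Cl)c2)cs1)c1ccc([N+](=O)[O-])o1` furthest at 43700 nM. Both steps, a 1.1-fold higher number from compound 1 to compound 2 (0.03 log units; within the scatter) and a 1.3-fold lower number from compound 1 to compound 3 (0.13 log units; within the scatter), lie within the scatter, as does a 1.4-fold lower number from compound 2 to compound 3 (0.16 log units; within the scatter). Compound 4 `O=C(Nc1nc(-c2cccc(Br)c2)cs1)c1ccc([N+](=O)[O-])o1` differs from compound 1 by bromo in place of methoxy on an aromatic carbon. The step from compound 1 to compound 3, a chloro in place of methoxy at the same place, bears most directly on this change and was small. For compound 4 a step of a 1.2-fold lower number from compound 1 to compound 4 (0.10 log units; within the scatter) is therefore expected in this assay, meaning no change beyond the scatter. The estimated value for compound 4 is 47000 nM, with a range from 20000 nM to 110000 nM.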

Compound 4, half-maximal inhibitory concentration: 71000 nM
The estimate for compound 4 lay 1.5-fold (0.18 log units) below the measured number, within the range that was stated.
By their numbers in this assay, from the lowest: compounds 3, 1, 2 and 4 (each within the scatter of the next).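

With bromo on this aromatic carbon, this assay again shows no change beyond the scatter, at a 1.2-fold higher number from compound 1 to compound 4 (0.08 log units; within the scatter). Bromo in place of chloro gives a 1.6-fold higher number from compound 3 to compound 4 (0.21 log units; within the scatter), and 3-bromophenyl in place of 4-methoxyphenyl gives a 1.1-fold higher number from compound 2 to compound 4 (0.05 log units; within the scatter), so methoxy, chloro and bromo read alike at this place among these four compounds. Nothing available offers a reason for this sameness. On these data alone, whether an amine or a carboxylic acid on this carbon would move the number beyond the scatter stays open. As far as these compounds go, all four compounds also share one core, so what that core itself contributes remains unknown.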